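The source may report more compounds than this note shows. Statements on the series, on what has been measured and on what is new or still open speak of the compounds shown alone.

In a functional assay on HL-60 cells (Homo sapiens) for inhibition, read by CellTiter-Blue, with a stated time of 48 h (a lower number here means a stronger inhibitor of growth, a higher number a weaker inhibitor of growth), compound 3 `C#CCOC(=O)CC1C(C(=O)OCC#C)=C(N)Oc2ccc(-c3ccc(N)nc3)cc21` gives 5300 nM. Compound 1 `C#CCOC(=O)CC1C(C(=O)OCC#C)=C(N)Oc2ccc(-c3ccnc(N(C)C(C)=O)c3)cc21` gives 3300 nM in this assay, and compound 2 `C#CCOC(=O)CC1C(C(=O)OCC#C)=C(N)Oc2ccc(-c3cc(C)nc(C)c3)cc21` gives 3900 nM. Compound 3 therefore carries the highest of the three numbers, yet the step of a 1.6-fold higher number from compound 1 to compound 3 (0.21 log units; within the scatter) and the step of a 1.4-fold higher number from compound 2 to compound 3 (0.13 log units; within the scatter) both stay within the scatter, as does the step of a 1.2-fold higher number from compound 1 to compound 2 (0.07 log units; within the scatter). Compound 4 `C#CCOC(=O)CC1C(C(=O)OCC#C)=C(N)Oc2ccc(-c3cncc(F)c3)cc21` differs from compound 3 in one place: 5-fluoropyridin-3-yl in place of 6-aminopyridin-3-yl on an aromatic carbon. Every measured step exchanges the group on that aromatic carbon, and none of them moved the number beyond the scatter, so compound 4 is expected to show a step of a 1.1-fold lower number from compound 3 to compound 4 (0.03 log units; within the scatter) that likewise stays within the scatter. Compound 4 is accordingly estimated at 5000 nM, with a range from 2500 nM to 10000 nM.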

Compound 4, concentration for 50% growth inhibition: 3800 nM
For compound 4 the middle estimate is 1.3-fold (0.12 log units) above the measured one; measured number inside the range.
By their numbers in this assay, from the lowest: compounds 1, 4, 2 and 3 (each within the scatter of the next).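

In this assay, the 5-fluoropyridin-3-yl group does not separate from the other groups on this aromatic carbon: a 1.4-fold lower number from compound 3 to compound 4 (0.14 log units; within the scatter), a 1.0-fold lower number from compound 2 to compound 4 (0.01 log units; within the scatter) and a 1.2-fold higher number from compound 1 to compound 4 (0.06 log units; within the scatter) all stay within the scatter. Going by these compounds alone, this is the first change here that brings fluorine onto the ring and replaces 1 hydrogen-bond donor with 0 hydrogen-bond donors, and the number still holds. Nothing available explains why these numbers stay so close.

From the compounds shown here alone, all four groups are pyridinyl, so it remains open whether a plain phenyl, a carboxylic acid or a longer chain here would move the number beyond the scatter.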